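Loss of one methoxy group: compound 3 to compound 4

The compounds below may be only part of what the source reports. "The series", "measured", "known", "first", "only" and "open" are said of these compounds alone.

Measured so far in a functional assay on U-87MG ATCC cells for antiproliferative activity against U-87 MG (Homo sapiens), read by MTT assay, with a stated time of 48 h, tested at 5 uM; on this read-out higher numbers stand for a weaker effect at the one concentration tested and lower numbers for a stronger effect:
compound 1 `COc1ccc(-c2nc(C)c(C(=O)CSc3nc(N)c(C#N)c(-c4ccc(OC)cc4)n3)s2)cc1` gives 35.6%
compound 2 `COc1ccc(-c2nc(SCC(=O)c3sc(-c4ccccc4)nc3C)[nH]c(=O)c2C#N)cc1OC` gives 80.8%
compound 3 `COc1ccc(-c2nc(SCC(=O)c3sc(-c4ccc(Cl)cc4)nc3C)[nH]c(=O)c2C#N)cc1OC` gives 93.4%

Compound 3 stands highest of the three numbers, meaning the weakest effect at the one concentration tested. Among the measured compounds shown here, its nearest neighbour is compound 2, and the one single-place step in the set is a number 12.6 percentage points higher from compound 2 to compound 3 (beyond the scatter). Compound 1, the furthest away, differs from compound 3 in more than one place, so only its value can be set beside it.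

Compound 4 `COc1cccc(-c2nc(SCC(=O)c3sc(-c4ccc(Cl)cc4)nc3C)[nH]c(=O)c2C#N)c1` differs from compound 3 by hydrogen in place of methoxy on an aromatic carbon. For the measured compounds named here, no measured step covers this change; the only step available concerns chloro in place of hydrogen. With nothing to point one way or the other, the expected step is a number 7.4 percentage points lower from compound 3 to compound 4 (within the scatter), not beyond the scatter. Compound 4 is therefore estimated at 86%, within 66% to 100%.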

Compound 4, a percentage reported as activity, at one concentration (the size of the read-out at that concentration, not a potency): 96.6%
The estimate for compound 4 lay 10.6 percentage points below the measured number; the range from low to high includes it.
By their numbers in this assay, from the lowest: compound 1; then compound 2; then compounds 3 and 4 (each within the scatter of the next).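

In this assay, going from 3,4-dimethoxyphenyl to 3-methoxyphenyl gives a number 3.2 percentage points higher from compound 3 to compound 4 (within the scatter), so this methoxy group can be replaced by hydrogen with no change beyond the scatter in this chloro-bearing pair. This is the first step shown at this aryl group; the earlier step concerned chloro in place of hydrogen on the other aromatic ring. No evidence on the origin of this result is available.

From the compounds shown here alone, whether a hydroxy group, an amine or a longer alkoxy chain at this place would shift the read-out remains open. Going by these compounds, the effect of replacing the remaining methoxy group is also open.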